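The source may hold more compounds than are shown below. What is called first, only, known or untested is meant among the compounds shown, and "the series" means these compounds.

Measured compounds:
compound 1 `OC[C@H]1O[C@@H](n2cnc3c(SCc4ccccc4Br)ncnc32)[C@H](O)[C@@H]1O` in an assay on K562 cells for displacement of a labelled ligand from Equilibrative nucleoside transporter 1 (Homo sapiens) (on this read-out lower numbers stand for stronger inhibition and higher numbers for weaker inhibition), gives 134 nM
compound 2 `OC[C@H]1O[C@@H](n2cnc3c(SCc4cccc(Br)c4)ncnc32)[C@H](O)[C@@H]1O` in this assay gives 20.5 nM

Within the data shown here, on these two numbers compound 2 stands lowest in this assay; its only neighbour is compound 1, separated by a 6.5-fold lower number from compound 1 to compound 2 (0.82 log units; beyond the scatter). Compound 3 `OC[C@H]1O[C@@H](n2cnc3c(SCc4ccc(Br)cc4)ncnc32)[C@H](O)[C@@H]1O` differs from compound 2 by 4-bromophenyl in place of 3-bromophenyl on a saturated chain carbon bound to a sulfur. Among the measured compounds shown here, the one step that bears on moving the bromine on this ring is a 6.5-fold lower number from compound 1 to compound 2 (0.82 log units; beyond the scatter), which lay beyond the scatter, but no measured pair covers 3-bromophenyl against 4-bromophenyl, so the direction is open. Compound 3 is therefore expected to stay close, with an estimated step of a 1.2-fold higher number from compound 2 to compound 3 (0.09 log units; within the scatter) and an estimated value of 25 nM (range 8 nM to 80 nM).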

Compound 3, inhibition constant: 9.98 nM
Compound 3: the middle estimate sits 2.5-fold (0.40 log units) above what was measured; low and high end bracket the measured number.
By their numbers in this assay, from the lowest: compound 3; then compound 2; then compound 1.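

In this assay the change from 3-bromophenyl to 4-bromophenyl gives a 2.1-fold lower number from compound 2 to compound 3 (0.31 log units; beyond the scatter) and so lies beyond the scatter, which settles the direction of this step. Together with a 13-fold lower number from compound 1 to compound 3 (1.13 log units; beyond the scatter) this puts the three bromine placements in one order, with 4-bromophenyl lowest, 3-bromophenyl next and 2-bromophenyl highest. Nothing available explains this order.

Going by these compounds, whether the same order holds with chlorine or a methoxy group in place of the bromine stays open. So does the effect of a longer chain in place of the saturated chain carbon bound to a sulfur.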